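Cyclohexyloxy to 4-methylphenoxy on the benzamide of compound 2

This account rests on a few compounds, and the source may have more. Where it says the series, first, only, none or still open, it means among the compounds named here.

Two compounds carry numbers in a functional assay on MIA PaCa-2 cells (Homo sapiens) for antiproliferative activity, read by MTT assay, with a stated time of 72 h (on this read-out lower numbers stand for an effect already at smaller amounts and higher numbers for an effect only at larger amounts of compound), so far. Compound 1 `Cc1nn(Cc2ccc(C(N)=O)cc2)c(C)c1NC(=O)c1ccc(COc2ccccc2)cc1` reaches only the limit of the assay, > 100000 nM, a limit and not a number; this is the case described by the limit of > 100000 nM in this assay, at which 1 of the 2 values shown sits. Among the compounds with values here, compound 2 `CNC(=O)c1cccc(Cn2nc(C)c(NC(=O)c3ccc(COC4CCCCC4)cc3)c2C)c1` gives 14000 nM in this assay, the only numerical value shown, with compound 1 differing from it in more than one place, so no single step can be read between them.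

Compound 3 `CNC(=O)c1cccc(Cn2nc(C)c(NC(=O)c3ccc(COc4ccc(C)cc4)cc3)c2C)c1` differs from compound 2 by 4-methylphenyl in place of cyclohexyl on an oxygen on a saturated carbon, in words 4-methylphenyl in place of cyclohexyl on an oxygen on a saturated carbon. Within the data shown here, no measured step covers this change. The expectation for compound 3 is a modest loss, with a step of a 1.8-fold higher number from compound 2 to compound 3 (0.25 log units; within the scatter) that may still sit near the scatter, and a real chance that this assay again returns only a limit. Compound 3 is therefore estimated at 25000 nM in this assay, within a range from 8000 nM to 80000 nM.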

Compound 3, half-maximal effective concentration: 2600 nM
Estimate against measurement, compound 3: 9.6-fold (0.98 log units) above; the whole stated range lies above it.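

In this assay the series now has its first readable single change: a 5.4-fold lower number from compound 2 to compound 3 (0.73 log units; beyond the scatter). This shows that the group on an oxygen on a saturated carbon is a place where one exchange moves the number beyond the usual scatter, and that 4-methylphenyl, an aromatic ring of carbon only, is accepted there with a lower number than cyclohexyl, a non-aromatic ring. Within the data shown here, nothing measured so far bears on the reason for this step.

As far as these compounds go, whether the lower number belongs to the aromatic ring itself or to the methyl on it remains open, as a single step cannot separate the two. Also open, from the compounds shown here alone, is how the same place responds to a 4-chlorophenyl, a pyridyl ring or a longer alkyl chain on that oxygen.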